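Five-membered ring swaps on the piperazine arm

The source may hold more compounds than are shown below. What is called first, only, known or untested is meant among the compounds shown, and "the series" means these compounds.

Measured so far:
compound 1 `CCc1nc(C)c(CN2CCN(c3cccc4[nH]c(-c5ccc(C(C)(C)C)cc5)nc34)CC2)o1` gives 37 nM in an assay on isolated protein for displacement of a labelled ligand from Gonadotropin-releasing hormone receptor (Homo sapiens); a higher number here means a weaker inhibitor, a lower number a stronger inhibitor
compound 2 `Cc1n[nH]c(C)c1CN1CCN(c2cccc3[nH]c(-c4ccc(C(C)(C)C)cc4)nc23)CC1` gives 68 nM in this assay
compound 3 `Cc1cc(CN2CCN(c3cccc4[nH]c(-c5ccc(C(C)(C)C)cc5)nc34)CC2)nn1C` gives 83 nM in this assay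

Compound 3 has the highest number of the three in this assay; against compound 2 the gap is within the scatter, against compound 1 it is beyond it, so compound 3 is the weakest of the set only relative to compound 1.

Compound 4 `CCc1nc(CN2CCN(c3cccc4[nH]c(-c5ccc(C(C)(C)C)cc5)nc34)CC2)cn1C` differs from compound 3 in one place: 2-ethyl-1-methyl-1H-imidazol-4-yl in place of 1,5-dimethyl-1H-pyrazol-3-yl on a saturated chain carbon bound to an amine nitrogen in a ring. Going by the values given here, three measured steps bear on this kind of exchange, all of them swaps of one five-membered aromatic ring with two hetero atoms for another at the same place: a 1.8-fold higher number from compound 1 to compound 2 (0.26 log units; within the scatter), a 2.2-fold higher number from compound 1 to compound 3 (0.35 log units; beyond the scatter) and a 1.2-fold higher number from compound 2 to compound 3 (0.09 log units; within the scatter). Every such swap stayed small, the largest being modest. A further ring exchange is therefore expected to move the number little; if anything, a step back toward the number of compound 1 is estimated, giving a 1.5-fold lower number from compound 3 to compound 4 (0.18 log units; within the scatter). For compound 4 the expected value in this assay is 55 nM, within 25 nM to 130 nM.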

Compound 4, half-maximal inhibitory concentration: 18 nM
Beside the measured number, compound 4's estimate is 3.1-fold (0.49 log units) above it, and the stated range ends above it.
By their numbers in this assay, from the lowest: compound 4; then compounds 1, 2 and 3 (each within the scatter of the next, the first and the last beyond it).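

Ring exchange on a saturated chain carbon bound to an amine nitrogen in a ring no longer stays small in this assay: 2-ethyl-1-methyl-1H-imidazol-4-yl gives a 4.6-fold lower number from compound 3 to compound 4 (0.66 log units; beyond the scatter) and a 3.8-fold lower number from compound 2 to compound 4 (0.58 log units; beyond the scatter) as well as a 2.1-fold lower number from compound 1 to compound 4 (0.31 log units; beyond the scatter) in the comparison with the third ring. All three steps lie beyond the scatter, which makes compound 4 the strongest of the four, even though the leaving 1,5-dimethyl-1H-pyrazol-3-yl and the entering ring have the same counts of hydrogen-bond donors and acceptors. No measurement on hand explains the gain.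

Open, going by these compounds, is whether the lower number follows the imidazole ring or its ethyl group. A propyl chain in place of that ethyl group, or 1-methyl-1H-imidazol-4-yl without it, would separate the two.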